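A few compounds are considered here, and "the series" means these few. Any claim that something is new, unique, unknown or untested is made for them only; others in the source may bear on it.

Measured so far in a functional assay on the whole organism with Mus musculus as the target; on this read-out higher numbers stand for higher potency (the scale is a negative logarithm) and lower numbers for lower potency:
compound 1 `CN1CCC(OC(=O)c2ccc(C#N)cc2)CC1` gives 1.65;
compound 2 `Cc1ccc(C(=O)OC2CCN(C)CC2)cc1` gives 1.17;
compound 3 `CN1CCC(OC(=O)c2ccc(Cl)cc2)CC1` gives 1.11.

Compound 3 holds the lowest of the three numbers, but its gap to compound 2 is within the scatter (a number 0.06 log units lower from compound 2 to compound 3 (within the scatter)); only compound 1 stands clearly apart (a number 0.54 log units lower from compound 1 to compound 3 (beyond the scatter)). Compound 4 `CN1CCC(OC(=O)c2ccc([N+](=O)[O-])cc2)CC1` is not yet measured. The change from compound 3 is nitro in place of chloro on an aromatic carbon. For the measured compounds named here, no measured step involves nitro. Going by the values given here, the steps that bear on it are the other exchanges at the same aromatic carbon: a number 0.48 log units lower from compound 1 to compound 2 (beyond the scatter) and a number 0.54 log units lower from compound 1 to compound 3 (beyond the scatter), both modest, while a number 0.06 log units lower from compound 2 to compound 3 (within the scatter) is no difference at all. Exchanges at this carbon have so far given steps of modest size at most, so a small upward step is expected, estimated as a number 0.29 log units higher from compound 3 to compound 4 (within the scatter). Compound 4 is estimated at 1.4, with a range from 0.95 to 1.85.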

Compound 4, logarithm of the reciprocal of the active concentration, log(1/C): 1.14
Compound 4: middle estimate off by 0.26 log units, on the high side; the range from low to high includes it.
By their numbers in this assay, from the lowest: compounds 3, 4 and 2 (each within the scatter of the next); then compound 1.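

In this assay, nitro on the aromatic carbon para to a large group shows no difference from chloro (a number 0.03 log units higher from compound 3 to compound 4 (within the scatter)) or from methyl (a number 0.03 log units lower from compound 2 to compound 4 (within the scatter)), so three different groups at this carbon now give values within the scatter of one another. Nitrile alone stands apart, and that separation now extends to nitro (a number 0.51 log units lower from compound 1 to compound 4 (beyond the scatter)). Nothing measured explains why nitrile differs from these three groups.

On these data alone, whether an amine, a carboxylic acid or a methoxy group at this carbon would fall with these three or with nitrile remains open.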